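Swapping the triazole arm for a trifluoromethylphenyl group

The compounds below may be only part of what the source reports. "The series", "measured", "known", "first", "only" and "open" are said of these compounds alone.

The study begins with two close relatives that share one core. Compound 1, `CCOC(=O)C1=Cc2ccccc2OC1(OCc1cn(CC(=O)Nc2ccccc2Br)nn1)C(F)(F)F`, carries a bromophenyl amide on the triazole arm, and compound 2, `CCOC(=O)C1=Cc2ccccc2OC1(OCc1cn(CC(=O)Nc2ccccc2F)nn1)C(F)(F)F`, carries a fluorophenyl amide in the same place. In a functional assay on MCF7 cells (Homo sapiens) for inhibition, read by MTT assay, with a stated time of 24 h (a higher number here means a weaker inhibitor, a lower number a stronger inhibitor), compound 1 reaches only the limit of the assay, > 150000 nM, so no number is known for it. In this assay compound 2 gives 42100 nM, the only actual number shown so far. The other value, that of compound 1, is a limit of the assay, as the limit of > 150000 nM in this assay, at which 1 of the 2 values shown sits, states. The change between them, an at least 3.5-fold lower number from compound 1 to compound 2 (0.55 log units; beyond the scatter), is fluoro in place of bromo on an aromatic carbon.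

Compound 3, `CCOC(=O)C1=Cc2ccccc2OC1(OCc1cn(-c2cccc(C(F)(F)F)c2)nn1)C(F)(F)F`, is a larger change: 3-(trifluoromethyl)phenyl in place of ((2-fluorophenyl)carbamoyl)methyl on an aromatic nitrogen. Among the compounds with values here, no measured step swaps the whole arm, so the single step from compound 1 to compound 2 bears on it only loosely. I therefore expect this assay for compound 3 to change little beyond the scatter, estimating a 1.1-fold lower number from compound 2 to compound 3 (0.02 log units; within the scatter) and a value of 40000 nM, within 8000 nM to 200000 nM.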

Compound 3, half-maximal inhibitory concentration: > 150000 nM
Compound 3 gave a limit, no number (the forecaster's own chance of this, stated with the estimate: 35%); middle value at least 3.7-fold (0.57 log units) away from the limit.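

Replacing ((2-fluorophenyl)carbamoyl)methyl with 3-(trifluoromethyl)phenyl on the aromatic nitrogen gives an at least 3.5-fold higher number from compound 2 to compound 3 (0.55 log units; beyond the scatter) in this assay. The earlier step changed only one halogen on the arm, whereas this one shows that exchanging the whole arm also moves the result, and here the change is in the weakening direction. The leaving group holds a hydrogen-bond donor and a hydrogen-bond acceptor and the entering group holds neither, but the ring substituent and the link to the nitrogen change in the same step, so this single comparison cannot assign the loss to any one part; compound 1 and compound 3 also cannot be read against each other, as each gives only a limit and no number: the limit of > 150000 nM in this assay, at which 2 of the 3 values shown sit.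

The compounds shown leave open which part of the arm matters: the amide, the methylene link or the substituent on the phenyl ring. A plain benzyl group on that nitrogen, a longer chain before the amide, or an arm ending in an amine or a carboxylic acid would each test a different part of this question.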